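Swapping the aryl group on the shared core of compound 1

The source may hold more compounds than are shown below. What is called first, only, known or untested is meant among the compounds shown, and "the series" means these compounds.

Compound 1 `CC(=O)N[C@@H]1CCC[C@H](C(=O)Nc2cc(-c3nnn4ccccc34)c(Cl)cn2)C1` is the amide with the smallest value in this set: in a physicochemical assay for lipophilicity, using the shake flask method, measured as octanol-water partition, at pH 7.4 (on this read-out higher numbers stand for higher lipophilicity and lower numbers for lower lipophilicity), compound 1 gives 2. Its nearest neighbour is compound 2 `CC(=O)N[C@@H]1CCC[C@H](C(=O)Nc2cc(-c3cnn4c3CC(C)(C)CC4)ccn2)C1`, which in this assay gives 3.1, a number beyond the scatter above compound 1. Furthest off stands compound 3 `CC(=O)N[C@@H]1CCC[C@H](C(=O)Nc2cc(-c3cnn4c3CC(C)(C)C4)c(C#N)cn2)C1`, which in this assay gives 3.2, again beyond the scatter above compound 1. No single-point step between measured compounds is available, so the spread among these three can only be read from the values themselves.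

Compound 4 `CC(=O)N[C@@H]1CCC[C@H](C(=O)Nc2cc(-c3cnc4n3CC(C)(C)C4)c(Cl)cn2)C1` is not yet measured. It differs from compound 1 on an aromatic carbon of the six-membered aromatic ring with one nitrogen, ortho to the chloro group, meta to the large group and opposite the ring nitrogen: a group of 10 heavy atoms (8 carbon, 2 nitrogen; one five-membered non-aromatic ring with 1 hetero atom, one five-membered aromatic ring with 2 hetero atoms) in place of a group of 9 heavy atoms (6 carbon, 3 nitrogen; one five-membered aromatic ring with 3 hetero atoms, one six-membered aromatic ring with 1 hetero atom), on an aromatic carbon. Compounds 2 and 3, which carry related dimethyl-substituted bicyclic groups at the same position, sit well above compound 1.

Compound 4 is therefore expected to move upward by about a number 1.00 log units higher from compound 1 to compound 4 (beyond the scatter), a step beyond the scatter. Compound 4 is estimated at 3, with a range from 2.5 to 3.5.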

Compound 4, distribution coefficient: 3.6
Compound 4: the middle estimate sits 0.60 log units below what was measured; the whole stated range lies below it.
By their numbers in this assay, from the lowest: compound 1; then compounds 2 and 3 (each within the scatter of the next); then compound 4.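

Working notes on the position ortho to the chloro group. In this assay, going by these compounds alone, the exchange on this aromatic carbon gives a number 1.60 log units higher from compound 1 to compound 4 (beyond the scatter) and is the first step in the set that isolates a single place on the shared core, showing that this position alone can carry a large change in the read-out. The chloro group stays in both compounds, and the entering group has 10 heavy atoms (8 carbon, 2 nitrogen) and 2 hydrogen-bond acceptors, while the leaving group has 9 heavy atoms (6 carbon, 3 nitrogen) and 3 hydrogen-bond acceptors. No measurement shown explains the size of this step.

Within the data shown here, with only one step at this position, the ring system, the nitrogen count and the heavy-atom count all change together, so their separate contributions remain unresolved. Also open, on these data alone, is how the read-out would respond at this same aromatic carbon to a simple phenyl ring, a morpholine or a carboxylic acid, and whether the step would hold with a nitrile in place of the chloro group.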